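Pyridin-2-yl for Thiophen-2-yl on a Shared Core

The source may report more compounds than this note shows. Statements on the series, on what has been measured and on what is new or still open speak of the compounds shown alone.

Compound 1, `Oc1ccc(-c2cc(-c3ccco3)nc(-c3ccccc3Cl)c2)cc1`: 5480 nM
Compound 2, `Oc1cccc(-c2cc(-c3ccc(Cl)cc3)nc(-c3cccs3)c2)c1`: 10500 nM
Compound 3, `Oc1ccc(-c2cc(-c3ccc(Cl)cc3)nc(-c3cccs3)c2)cc1`: 6450 nM

All three were tested in a functional assay on T47D cells (Homo sapiens) for cytotoxicity, read by CCK-8 assay and cell counting, with a stated time of 2 days; a higher number here means a weaker inhibitor, a lower number a stronger inhibitor. Compound 2 gives the highest of the three numbers, yet its step to compound 3, a 1.6-fold lower number from compound 2 to compound 3 (0.21 log units; within the scatter), and its gap to compound 1 both lie within the scatter, so no order among them can be claimed. Compound 4, `Oc1cccc(-c2cc(-c3ccc(Cl)cc3)nc(-c3ccccn3)c2)c1`, differs from compound 2 by pyridin-2-yl in place of thiophen-2-yl on an aromatic carbon. Among the measured compounds shown here, the single measured step concerns the hydroxyphenyl group, not this exchange, so no measured step bears on it. Compound 4 is therefore expected to sit close to compound 2, with an expected step of a 1.1-fold lower number from compound 2 to compound 4 (0.02 log units; within the scatter), none beyond the scatter. The estimate for compound 4 is 10000 nM, ranging from 3500 nM to 30000 nM.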

Compound 4, half-maximal inhibitory concentration: 13900 nM
Estimate against measurement, compound 4: 1.4-fold (0.14 log units) below, within the range that was stated.
By their numbers in this assay, from the lowest: compounds 1, 3, 2 and 4 (each within the scatter of the next, the first and the last beyond it).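

In this assay the exchange of thiophen-2-yl for pyridin-2-yl, next to the ring nitrogen, gives a 1.3-fold higher number from compound 2 to compound 4 (0.12 log units; within the scatter) and so stays within the scatter. Among the compounds shown here, this is the first measured step at this position, and it shows that a six-membered aromatic ring can stand in place of a five-membered one without a change beyond the scatter. No other kind of measurement bears on this result. From the compounds shown here alone, what stays open is how this position would respond to a group that is not an aromatic ring, such as an amine or a carboxylic acid. Also open, going by these compounds, is whether the same exchange would read alike alongside a 4-hydroxyphenyl group.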